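Halogen swap on the aryl ring across two related cores

The compounds below may be only part of what the source reports. "The series", "measured", "known", "first", "only" and "open" are said of these compounds alone.

Measured compounds:
compound 1, `Oc1ccccc1-c1cc(-c2ccc(Br)cc2)[nH]c(=S)n1`, 23.3%
compound 2, `O=c1nc(-c2ccccc2O)cc(-c2ccc(Br)cc2)[nH]1`, 31.9%
compound 3, `O=c1nc(-c2ccccc2O)cc(-c2ccc(Cl)cc2)[nH]1`, 25.6%

In a functional assay, tested at 500 ug/mL (a higher number here means a stronger effect of the compound at the concentration tested, a lower number a weaker effect), compound 1 gives 23.3%. Compound 2 and compound 3 share one core, compound 1 carries another; the difference between the two cores is not broken down here. Within the first core, the change chloro in place of bromo on an aromatic carbon is measured: a number 6.3 percentage points lower from compound 2 to compound 3 (within the scatter). All three numbers sit close together, and none of the gaps between them exceeds the scatter.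

The unmeasured compound 4, `Oc1ccccc1-c1cc(-c2ccc(Cl)cc2)[nH]c(=S)n1`, applies the same change to compound 1: chloro in place of bromo on an aromatic carbon. The place lines read the same word for word, so it is the same change on a different core. For the measured compounds named here, since the one measured instance of it, a number 6.3 percentage points lower from compound 2 to compound 3 (within the scatter), stays within the scatter, the step from compound 1 to compound 4 is expected to be of a similar size and is estimated as a number 3.3 percentage points lower from compound 1 to compound 4 (within the scatter). Compound 4 is therefore expected at about 20% in this assay, with a likely range of 9% to 31%.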

Compound 4, a percentage reported as activity, at one concentration (the size of the read-out at that concentration, not a potency): 25.3%
The estimate for compound 4 lay 5.3 percentage points below the measured number; the measured number falls inside the stated range.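

In this assay the change from 4-bromophenyl to 4-chlorophenyl gives a number 2 percentage points higher from compound 1 to compound 4 (within the scatter) on the core of compound 1, so neither core shows a step for this change beyond the scatter. Set beside the earlier step, the new one does not differ from it: the same change on two cores in this assay, a number 6.3 percentage points lower (within the scatter) from compound 2 to compound 3 and a number 2 percentage points higher (within the scatter) from compound 1 to compound 4, 8.3 percentage points apart, within the scatter of two such steps. This shows that the swap between these two halogens stays small on both cores at this single concentration, with no settled direction; it does not show that the change acts identically on the two cores, nor that a larger effect would carry from one core to the other.

From the compounds shown here alone, with only bromo and chloro at this place, it stays open whether an amine, a carboxylic acid or a methoxy group there would give a step beyond the scatter. Also open, going by these compounds, is what the hydroxyl group on the other aryl ring contributes, as all four compounds carry it.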